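The source may report more compounds than this note shows. Statements on the series, on what has been measured and on what is new or still open speak of the compounds shown alone.

The measured compounds and their values:

Compound 1, `CCCCC/C=C/CCCCCCCCCC1(C(=O)OC)CO1`: 10 mg/kg
Compound 2, `CCCCCCC1(C(=O)OC)CO1`: 10 mg/kg
Compound 3, `CCCCCCCCCCCCCCCCCCC1(C(=O)OC)CO1`: 10 mg/kg

In a functional assay on the whole organism with Rattus norvegicus as the target, in the glucose tolerance test (a higher number here means that more compound is needed for the effect, a lower number that less compound is needed), compound 3 gives 10 mg/kg. This stands level with compounds 1 and 2 at the digits shown: the nearest is compound 1, with no change within the scatter, and the furthest is compound 2, again with no change within the scatter. Three compounds sharing one core thus give one and the same reading in this assay.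

Compound 4, `CCCCCCCCCCCC1(C(=O)OC)CO1`, is the next compound. It differs from compound 3 by hydrogen in place of heptyl on a saturated chain carbon, ten or more bonds along the chain from a saturated ring carbon.

Going by the values given here, no step between measured compounds is given for this pair, so the expectation rests on the three values shown. Because compound 2 gives 10 mg/kg and compound 3 gives 10 mg/kg, the same reading across a shared core, the step from compound 3 to compound 4 is expected to be none beyond the scatter, no change at the digits printed from compound 3 to compound 4 (within the scatter). For compound 4 the estimate in this assay is 10 mg/kg, with a range from 5 mg/kg to 20 mg/kg.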

Compound 4, minimum effective dose: 10 mg/kg
Compound 4: middle estimate and measured number agree at the digits printed; low and high end bracket the measured number.
By their numbers in this assay, from the lowest: compounds 1, 2, 3 and 4 (each within the scatter of the next).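

In this assay, hydrogen in place of heptyl on a saturated chain carbon, ten or more bonds along the chain from a saturated ring carbon, brings no change at the digits printed from compound 3 to compound 4 (within the scatter). Pentyl in place of hydrogen on a saturated chain carbon, six bonds along the chain from a saturated ring carbon, brings no change at the digits printed from compound 2 to compound 4 (within the scatter), and ethyl in place of hept-1-en-1-yl on a saturated chain carbon, nine bonds along the chain from a saturated ring carbon, brings no change at the digits printed from compound 1 to compound 4 (within the scatter). Going by these compounds alone, compound 4 thus supplies the first single-place comparisons, and none of the three chain changes moves the reading beyond the scatter.

The compounds shown leave open whether a carboxylic acid or an amide in place of the ester would keep this reading. They also leave open whether an amine at the chain end would do so.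

No measurement at hand explains why the reading stays the same.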